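The source may hold more compounds than are shown below. What is called first, only, known or untested is meant among the compounds shown, and "the series" means these compounds.

Compound 1 `COc1cc2c(Nc3ccc(NC(=O)Nc4ccccc4)cc3)ncnc2cc1OCc1ccccc1`: > 50000 nM
Compound 2 `COc1cc2c(Nc3ccc(NC(=O)Nc4ccc(C)c(C)c4)cc3)ncnc2cc1OCc1ccccc1`: > 50000 nM

In a functional assay on HT-29 cells (Homo sapiens) for antiproliferative activity, read by MTT assay, with a stated time of 48 h (on this read-out higher numbers stand for weaker inhibition and lower numbers for stronger inhibition), compound 1 gives > 50000 nM, which is a limit of the assay and not a number. Compound 2 likewise stands at a limit. Among the measured compounds shown here, the one measured step, a step that the two limits leave unreadable from compound 1 to compound 2, cannot be read because of the limit of > 50000 nM in this assay, at which 2 of the 2 values shown sit. Compound 3 `COc1cc2c(Nc3ccc(NC(=O)Nc4ccccc4)cc3)ncnc2cc1OCCCN1CCN(C)CC1` differs from compound 1 by 2-(4-methylpiperazin-1-yl)ethyl in place of phenyl on a saturated chain carbon bound to an oxygen on an aromatic ring. For the measured compounds named here, no measured step touches this position, so the data give no direction for the change. Compound 3 is expected at 20000 nM, with a range from 2000 nM to 50000 nM. This estimate means a step of an at least 2.5-fold lower number from compound 1 to compound 3 (0.39 log units; beyond the scatter), and it rests on uncertainty rather than on measured evidence.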

Compound 3, half-maximal inhibitory concentration: 49400 nM
The estimate for compound 3 lay 2.5-fold (0.39 log units) below the measured number; measured number inside the range.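

In this assay, replacing benzyloxy with 3-(4-methylpiperazin-1-yl)propoxy gives the first readable number, a step of an at least 1.0-fold lower number from compound 1 to compound 3 (0.00 log units; that floor lies within the scatter). The value of compound 1 is a limit and not a number. The step can therefore be stated only as a floor, and no lowering beyond the scatter is shown: the limit of > 50000 nM in this assay, at which 2 of the 3 values shown sit.

The compounds shown leave open whether 3-(morpholin-4-yl)propoxy in the same place would give a lower number than compound 3. They also leave open how the 3,4-dimethylphenyl of compound 2 would behave alongside 3-(4-methylpiperazin-1-yl)propoxy.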